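Cyano in place of methylsulfanyl: expectation for compound 4

A few compounds are considered here, and "the series" means these few. Any claim that something is new, unique, unknown or untested is made for them only; others in the source may bear on it.

Measured so far:
compound 1 `CCC(C)(C)/N=c1\c(O)c(O)\c1=N/Cc1ccc(SC)cc1`: in a functional assay for inhibition, with Rattus norvegicus as the target (on this read-out higher numbers stand for weaker inhibition and lower numbers for stronger inhibition), compound 1 gives 5600 nM.
compound 2 `CCC(C)(C)/N=c1\c(O)c(O)\c1=N/Cc1ccc(C)c(C)c1`: in this assay compound 2 gives only a limit, > 30000 nM, not a number.
compound 3 `CN(c1c(NCc2ccc(C#N)cc2)c(=O)c1=O)C(C)(C)C`: in this assay compound 3 gives 18300 nM.

Compound 1 holds the lowest of the two numbers; compound 3 lies a gap beyond the scatter above it. Compound 2 reports only a limit (the limit of > 30000 nM in this assay, at which 1 of the 3 values shown sits).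

Compound 4 `CCC(C)(C)/N=c1\c(O)c(O)\c1=N/Cc1ccc(C#N)cc1` differs from compound 1 by cyano in place of methylsulfanyl on an aromatic carbon. Among the compounds with values here, no measured pair covers this change; compound 3 carries a cyano but on a different core, so its value is no guide to the swap. The step from compound 1 to compound 4 is expected to be a 1.6-fold higher number from compound 1 to compound 4 (0.21 log units; within the scatter), a modest weakening. Compound 4 is expected to give 9000 nM, between 3000 nM and 30000 nM.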

Compound 4, half-maximal inhibitory concentration: 1100 nM
Compound 4: middle estimate off by 8.2-fold (0.91 log units), on the high side; measured number outside the range, below it.
By their numbers in this assay, from the lowest: compound 4; then compound 1; then compound 3. At a limit, above all of these: compound 2.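

Cyano in place of methylsulfanyl on this aromatic carbon gives a 5.1-fold lower number from compound 1 to compound 4 (0.71 log units; beyond the scatter) in this assay, so inhibition on the shared core responds to the group held para to a large group. Within the data shown here, it also shows that this position can move toward stronger inhibition, which no earlier pair could show. Nothing measured here gives a cause for this step.

Open, from the compounds shown here alone, is whether an amine, a carboxylic acid or a longer chain at this carbon would go further than cyano. Also open, going by these compounds, is whether the same swap holds on the core of compound 3.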